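Aryl ketone variation on the chalcone-type series

The source may hold more compounds than are shown below. What is called first, only, known or untested is meant among the compounds shown, and "the series" means these compounds.

The three measured compounds share one core, differing only in the ring on the carbonyl carbon. Compound 3 `O=C(/C=C/c1cn(-c2ccccc2)nc1-c1ccncc1)c1ccccc1` gives the lowest number in a functional assay on Huh-7 cells (Homo sapiens) for inhibition, read by sulforhodamine B assay, with a stated time of 72 h (on this read-out lower numbers stand for stronger inhibition and higher numbers for weaker inhibition), at 1800 nM, though compound 1 `O=C(/C=C/c1cn(-c2ccccc2)nc1-c1ccncc1)c1ccsc1` at 2200 nM sits alongside it, the step of a 1.2-fold lower number from compound 1 to compound 3 (0.09 log units; within the scatter) being within the scatter. Compound 2 `O=C(/C=C/c1cn(-c2ccccc2)nc1-c1ccncc1)c1cc[nH]c1` at 28800 nM is far weaker, the step of a 16-fold lower number from compound 2 to compound 3 (1.20 log units; beyond the scatter) being large. Compound 4 `COc1ccc(C(=O)/C=C/c2cn(-c3ccccc3)nc2-c2ccncc2)cc1OC` carries the change (3,4-dimethoxyphenyl in place of phenyl on a carbonyl carbon). Within the data shown here, none of the measured steps adds substituents to an aryl ring; they only exchange the ring itself, and the step from compound 1 to compound 3 shows that two all-carbon-or-sulfur aryl rings behave alike. For compound 4 no step beyond the scatter is therefore expected, a 1.2-fold lower number from compound 3 to compound 4 (0.08 log units; within the scatter), giving an estimate of 1500 nM with a range of 500 nM to 4500 nM.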

Compound 4, half-maximal inhibitory concentration: 2000 nM
Beside the measured number, compound 4's estimate is 1.3-fold (0.12 log units) below it; measured number inside the range.
By their numbers in this assay, from the lowest: compounds 3, 4 and 1 (each within the scatter of the next); then compound 2.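

Substitution on the aryl ring appears here for the first time: on the carbonyl carbon, 3,4-dimethoxyphenyl in place of phenyl leaves the number in this assay unchanged within the scatter (a 1.1-fold higher number from compound 3 to compound 4 (0.05 log units; within the scatter)), and the same holds against thiophen-3-yl (a 1.1-fold lower number from compound 1 to compound 4 (0.04 log units; within the scatter)). Compound 2 alone stands apart (a 14-fold lower number from compound 2 to compound 4 (1.16 log units; beyond the scatter)), so the larger substituted ring is accepted at this position. Nothing available explains either the flat steps or the large one. Still open, from the compounds shown here alone, is whether an amine, a carboxylic acid or a longer chain on the phenyl ring would leave the number equally unchanged.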